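Adding a Carboxy Group to the Hydroxyethyl Amine

This account rests on a few compounds, and the source may have more. Where it says the series, first, only, none or still open, it means among the compounds named here.

Compound 2 `COc1ccc(/C=C\c2cc(OC)c(OC)c(OC)c2)cc1OCc1ccc(CNCCO)cc1` is the starting point. For the measured compounds named here, in a functional assay on HepG2 cells (Homo sapiens) for antiproliferative activity, read by CCK-8 assay, with a stated time of 48 h (on this read-out higher numbers stand for weaker inhibition and lower numbers for stronger inhibition), compound 2 gives 5900 nM, the second highest of the three numbers so far. Compound 1 `COc1ccc(/C=C\c2cc(OC)c(OC)c(OC)c2)cc1OCc1ccc(CNC(C)(C)C(=O)O)cc1` gives 6500 nM, and compound 3 `COc1ccc(/C=C\c2cc(OC)c(OC)c(OC)c2)cc1OCc1ccc(CN2CCCCC2C(=O)NCCNC(=O)OC(C)(C)C)cc1` gives 1100 nM, the lowest of the three. The change to compound 4 `COc1ccc(/C=C\c2cc(OC)c(OC)c(OC)c2)cc1OCc1ccc(CN[C@H](C(=O)O)[C@@H](C)O)cc1` is 1-carboxy-2-hydroxypropyl in place of 2-hydroxyethyl on an amine nitrogen. Going by the values given here, the one step that bears on it, a 1.1-fold lower number from compound 1 to compound 2 (0.04 log units; within the scatter), exchanged a carboxy-bearing group for the hydroxyethyl and hardly moved the number; compound 3 carries a different, larger group, and its lower number is not a single step from compound 2. No step beyond the scatter is therefore expected: compound 4 is estimated at 6000 nM, between 2500 nM and 14000 nM, which means a 1.0-fold higher number from compound 2 to compound 4 (0.01 log units; within the scatter).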

Compound 4, half-maximal inhibitory concentration: > 10000 nM
Compound 4: a limit, no number; the forecaster's own chance of this, stated with the estimate: 5%; at least 1.6-fold (0.22 log units) between middle value and limit.
By their numbers in this assay, from the lowest: compound 3; then compounds 2 and 1 (each within the scatter of the next). At a limit, above all of these: compound 4.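

In this assay compound 4 gives a limit of the assay, not a number, and it is the only compound shown to do so: the limit of > 10000 nM in this assay, at which 1 of the 4 values shown sits. The floors of an at least 1.6-fold higher number from compound 2 to compound 4 (0.22 log units; that floor lies within the scatter) and of an at least 1.5-fold higher number from compound 1 to compound 4 (0.18 log units; that floor lies within the scatter) both lie within the scatter, so 1-carboxy-2-hydroxypropyl on this amine nitrogen is not shown to weaken inhibition, and the true size of each step stays unknown. Nothing here shows this change strengthening inhibition either.

As far as these compounds go, what a methyl ester of the carboxylic acid or a longer hydroxyalkyl chain would give on this nitrogen remains open.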